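Aryl variation on the shared core, glucagon receptor inhibition

The compounds below may be only part of what the source reports. "The series", "measured", "known", "first", "only" and "open" are said of these compounds alone.

Measured so far:
compound 1, `CCCCCc1c(C(C)C)nc(C(C)C)c(CO)c1-c1cccc(C)c1`: 46%
compound 2, `CCCCCc1c(C(C)C)nc(C(C)C)c(CO)c1-c1ccccc1C`: 33%

Both were tested in an assay on CHO cells for inhibition of Glucagon receptor (Homo sapiens), tested at 20 uM; on this read-out lower numbers stand for less inhibition and higher numbers for more inhibition at the one concentration tested (going by the name of the read-out). For the measured compounds named here, compound 2 holds the lower of the two numbers; the one step on record, a number 13 percentage points lower from compound 1 to compound 2 (beyond the scatter), lies beyond the scatter. Compound 3, `CCCCCc1c(C(C)C)nc(C(C)C)c(CO)c1-c1ccc(Cl)cc1Cl`, is not yet measured. The change is 2,4-dichlorophenyl in place of 2-methylphenyl on an aromatic carbon. Going by the values given here, no measured step covers this exchange; the only known step swaps one methylphenyl for another, so it gives little guidance in this assay, and a modest step in either direction, or none beyond the scatter, is plausible. For compound 3 a value of 40% is expected, within 15% to 65%. The step of a number 7 percentage points higher from compound 2 to compound 3 (within the scatter) is what this estimate means, expected only tentatively.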

Compound 3, a percentage reported as inhibition, at one concentration (the size of the read-out at that concentration, not a potency): 8%
The estimate for compound 3 lay 32 percentage points above the measured number, outside the stated range (below it).
By their numbers in this assay, from the lowest: compound 3; then compound 2; then compound 1.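

In this assay, the aryl group opposite the ring nitrogen can do more than the shift of one methyl showed: 2,4-dichlorophenyl gives a number 25 percentage points lower from compound 2 to compound 3 (beyond the scatter), and a number 38 percentage points lower from compound 1 to compound 3 (beyond the scatter). Of the three aryl groups, 2,4-dichlorophenyl therefore holds the lowest number, with both steps beyond the scatter. No supporting data bear on what lies behind this drop.

Going by these compounds, since the exchange replaces the methyl and adds a second chlorine at once, the part played by each chlorine stays open. Also open, on these data alone, is how an aryl group carrying an amine or a carboxylic acid would read at this position.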